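The compounds below may be only part of what the source reports. "The series", "measured", "known", "first", "only" and "open" are said of these compounds alone.

Working notes on the series.

Compound 1, `Cc1nc(C(F)(F)F)ccc1CNC(=O)C(C)c1ccc(NS(C)(=O)=O)c(F)c1`, in an assay on CHO cells for antagonist activity at transient receptor potential cation channel subfamily V member 1 (Homo sapiens), read by FLIPR and calcium flux (on this read-out lower numbers stand for stronger inhibition and higher numbers for weaker inhibition), gives 387 nM. Compound 2, `CCCCCCc1nc(C(F)(F)F)ccc1CNC(=O)C(C)c1ccc(NS(C)(=O)=O)c(F)c1`, in this assay gives 1.6 nM. Among the compounds with values here, the one step available, a 240-fold lower number from compound 1 to compound 2 (2.38 log units; beyond the scatter), is the whole of what the two numbers show: compound 2 stands lowest of the two and is the reference point for what follows.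

Compound 3, `CC(C(=O)NCc1ccc(C(F)(F)F)nc1CCC(C)(C)C)c1ccc(NS(C)(=O)=O)c(F)c1`, shares all atoms with compound 2 and differs only in how they are joined: tert-butyl in place of butyl on a saturated chain carbon, two bonds along the chain from an aromatic carbon. Seen one bond further out, the hexyl of compound 2 becomes a 3,3-dimethylbutyl.

The step of a 240-fold lower number from compound 1 to compound 2 (2.38 log units; beyond the scatter) bears on this change only indirectly; it shows that a chain at this position moves the number strongly, but it says nothing about rearranging the same atoms within that chain. The size of a step for such a rearrangement is therefore not fixed by anything measured here. Compound 3 is expected to stay near compound 2, with a step of a 1.9-fold higher number from compound 2 to compound 3 (0.27 log units; within the scatter) that may well lie within the scatter and at most a modest rise. The estimate for compound 3 in this assay is 3 nM, between 0.8 nM and 12 nM.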

Compound 3, inhibition constant: 0.6 nM
Compound 3: the middle estimate sits 5.0-fold (0.70 log units) above what was measured; the measured number lies below the stated range.
By their numbers in this assay, from the lowest: compound 3; then compound 2; then compound 1.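

Rearranging the same atoms within the chain moves the number in this assay, and tert-butyl in place of butyl, two bonds along the chain from an aromatic carbon, gives a 2.7-fold lower number from compound 2 to compound 3 (0.43 log units; beyond the scatter) as a modest step. This position therefore responds not only to the presence of a chain but also to how its atoms are joined, at least for this one pair of isomeric chains. Measured against the small starting compound, the 3,3-dimethylbutyl chain gives a 650-fold lower number from compound 1 to compound 3 (2.81 log units; beyond the scatter) and the hexyl chain gives a 240-fold lower number from compound 1 to compound 2 (2.38 log units; beyond the scatter) so that the large gain survives the rearrangement and the branched chain goes slightly further, while nothing available explains the difference between the two chains.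

Still open, on these data alone, is how the number behaves with a longer chain such as octyl, or with a chain ending in a cyclohexyl ring, a tertiary amine or a carboxylic acid. Also open, as far as these compounds go, is whether branching at a different carbon of the chain, as in an isopropyl or a 2-methylpentyl group, would give a step of the same direction.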